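The compounds below may be only part of what the source reports. "The series", "measured", "known", "first", "only" and "open" are said of these compounds alone.

Measured so far:
Compound 1 `COc1cc(CNCc2ccccc2)ccc1OCc1ccc(Cl)nc1`: 90000 nM
Compound 2 `COc1cc(CNCc2ccncc2)ccc1OCc1ccccc1F`: 5100 nM

In a functional assay on HeLa cells (Homo sapiens) for inhibition, with a stated time of 72 h (a higher number here means that more compound is needed for the effect, a lower number that less compound is needed), compound 2 gives 5100 nM, the lower of the two numbers. Compound 1 gives 90000 nM, and the gap between the two lies beyond the scatter. The next compound to be tested is compound 3 `COc1cc(CNCc2ccncc2)ccc1OCc1ccc(Cl)c(Cl)c1`, which has 3,4-dichlorophenyl in place of 2-fluorophenyl on a saturated chain carbon bound to an oxygen on an aromatic ring. Among the measured compounds shown here, no measured pair differs in only one place, so the data give no direct guide to this change, and the expectation is tentative. A moderate move toward a lower number in this assay seems most likely, though a result within the scatter or a move upward would not be surprising. The estimated step is a 2.0-fold lower number from compound 2 to compound 3 (0.31 log units; beyond the scatter). For compound 3 the expected value is 2500 nM, with an estimated range of 600 nM to 10000 nM.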

Compound 3, half-maximal effective concentration: 4000 nM
Compound 3: middle estimate off by 1.6-fold (0.20 log units), on the low side; the measured number falls inside the stated range.
By their numbers in this assay, from the lowest: compounds 3 and 2 (each within the scatter of the next); then compound 1.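

In this assay, the first single-place change among these compounds gives a 1.3-fold lower number from compound 2 to compound 3 (0.11 log units; within the scatter), so the number does not separate 2-fluorobenzyl from 3,4-dichlorobenzyl. On a saturated chain carbon bound to an oxygen on an aromatic ring, then, this assay reads 2-fluorophenyl and 3,4-dichlorophenyl alike, even though the swap replaces fluorine with chlorine and changes the size of the group. Nothing measured here offers an explanation for this result.

The compounds shown leave open whether a single chlorine, a methoxy group or an unsubstituted phenyl at this place would also stay within the scatter, and whether a carboxylic acid or a longer chain would move the number. Compound 1 differs from compound 2 in more than one place, so its higher number cannot be assigned to any single part of the structure.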